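The source may report more compounds than this note shows. Statements on the series, on what has been measured and on what is new or still open speak of the compounds shown alone.

Among the compounds with values here, in an ADME assay on ECV-304 cells (Homo sapiens) for cytotoxicity, read by MTT assay, with a stated time of 72 h (a higher number here means a weaker inhibitor, a lower number a stronger inhibitor), compound 2 `COc1ccc(C2=C(c3cc(OC)c(OC)c(OC)c3)C(=O)C(OC(C)=O)C2)cc1Cl` gives 3.5 ug/mL and holds the lowest of the two numbers so far, while compound 1 `COc1ccc(C2=C(c3cc(OC)c(OC)c(OC)c3)C(=O)C(OC(C)=O)C2)cc1F` gives 41 ug/mL as the higher one. Compound 3 `COc1ccc(C2=C(c3cc(OC)c(OC)c(OC)c3)C(=O)C(OC(C)=O)C2)cc1O` comes next, with the difference hydroxy in place of chloro on an aromatic carbon in one place: hydroxy in place of chloro on an aromatic carbon, ortho to a methoxy group. Within the data shown here, only one measured step bears on this carbon, namely a 12-fold lower number from compound 1 to compound 2 (1.07 log units; beyond the scatter) for chloro in place of fluoro. Among the measured compounds shown here, that step is large, so the number in this assay can move far with the group here, but no measured compound carries hydroxy, and no direction follows from it. A step of similar size either way remains possible. The estimated step is a 1.2-fold lower number from compound 2 to compound 3 (0.07 log units; within the scatter) at the middle of a wide range. For compound 3 the expected value is 3 ug/mL with an estimated range of 0.4 ug/mL to 30 ug/mL in this assay.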

Compound 3, half-maximal inhibitory concentration: > 100 ug/mL
Compound 3: only a limit was reported; the forecaster's own chance of this, stated with the estimate: 3%; middle value at least 33-fold (1.52 log units) from the limit.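

At this carbon, ortho to a methoxy group, replacing chloro with hydroxy gives an at least 28-fold higher number from compound 2 to compound 3 (1.45 log units; beyond the scatter), and replacing fluoro with hydroxy gives an at least 2.4-fold higher number from compound 1 to compound 3 (0.38 log units; beyond the scatter). The three groups therefore fall in one order in this small set, with chloro lowest, fluoro in the middle and hydroxy highest, each gap beyond the scatter, so the sensitivity of this position is not confined to an exchange between halogens. In this assay compound 3 is reported only as a limit, not as a number: the limit of > 100 ug/mL in this assay, at which 1 of the 3 values shown sits.

Going by these compounds, the true size of both steps into compound 3 therefore stays open, as each is only a bound. Also open, on these data alone, is where an amine, a methyl group or a bromine at this carbon would fall in the order, and whether that order holds on a changed core.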